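Compound 3 to compound 4: amide link replaced

The source may report more compounds than this note shows. Statements on the series, on what has been measured and on what is new or still open speak of the compounds shown alone.

Values in a functional assay on MIA PaCa-2 cells (Homo sapiens) for antiproliferative activity; a higher number here means that more compound is needed for the effect, a lower number that less compound is needed:
- compound 1 `Cc1cc2c(C(=O)NCCC#N)cccc2n1-c1nc2c(c(NCc3ccccc3)n1)CCCC2`: 517 nM
- compound 2 `CC#CCNC(=O)c1cccc2c1cc(C)n2-c1nc2c(c(NCc3ccccc3)n1)CCCC2`: 723 nM
- compound 3 `CCCNC(=O)c1cccc2c1cc(C)n2-c1nc2c(c(NCc3ccccc3)n1)CCCC2`: 608 nM
- compound 4 `CC#CC(=O)Nc1cccc2c1cc(C)n2-c1nc2c(c(NCc3ccccc3)n1)CCCC2`: not yet measured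

Compound 3, at 608 nM, lies within the scatter of the other two measured compounds: a 1.2-fold higher number from compound 1 to compound 3 (0.07 log units; within the scatter) and a 1.2-fold lower number from compound 2 to compound 3 (0.08 log units; within the scatter). Compound 4 carries ((prop-1-yn-1-yl)carbonyl)amino in place of propylcarbamoyl on an aromatic carbon. The measured steps, including a 1.4-fold higher number from compound 1 to compound 2 (0.15 log units; within the scatter), change only the chain end on the amide nitrogen. None tests this replacement, so they give no direction for it. No step beyond the scatter is expected in this assay, though with wide uncertainty. The expected step is a 1.5-fold higher number from compound 3 to compound 4 (0.17 log units; within the scatter). Compound 4 is estimated at 900 nM, with an expected range of 250 nM to 3000 nM.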

Compound 4, half-maximal effective concentration: 436 nM
The estimate for compound 4 lay 2.1-fold (0.31 log units) above the measured number, and the stated range covers the measured number.
By their numbers in this assay, from the lowest: compounds 4, 1, 3 and 2 (each within the scatter of the next).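

In this assay the amide link on this aromatic carbon can be reversed, with ((prop-1-yn-1-yl)carbonyl)amino replacing propylcarbamoyl, and the result is a 1.4-fold lower number from compound 3 to compound 4 (0.14 log units; within the scatter) and no step beyond the scatter. Against the other two side chains, a 1.7-fold lower number from compound 2 to compound 4 (0.22 log units; within the scatter) and a 1.2-fold lower number from compound 1 to compound 4 (0.07 log units; within the scatter) also keep the reversed link within the scatter of each compound with the original orientation. No supporting data explain this outcome.

The compounds shown leave open how an acetyl or butanoyl group on the reversed amide nitrogen would compare. From the compounds shown here alone, a carboxylic acid or primary amine on this aromatic carbon also remains open.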